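Swapping furan for thiophene on a shared nucleoside core

The compounds below may be only part of what the source reports. "The series", "measured", "known", "first", "only" and "open" are said of these compounds alone.

Compound 1 `Nc1nc(N)c2c(-c3ccoc3)cn([C@@H]3O[C@H](CO)[C@@H](O)[C@H]3O)c2n1` gives only a limit: > 100000 nM
Compound 2 `COc1ncnc2c1c(-c1ccoc1)cn2[C@@H]1O[C@H](CO)[C@@H](O)[C@H]1O` gives 29400 nM
Compound 3 `COc1nc(N)nc2c1c(-c1ccoc1)cn2[C@@H]1O[C@H](CO)[C@@H](O)[C@H]1O` gives only a limit: > 100000 nM

All values come from an ADME assay on MRC5 cells (Homo sapiens), read by MTT assay, with a stated time of 72 h; on this read-out higher numbers stand for weaker inhibition and lower numbers for stronger inhibition. Compound 3 stands at a limit, not a number, the same limit described by the limit of > 100000 nM in this assay, at which 2 of the 3 values shown sit. The step that the two limits leave unreadable from compound 1 to compound 3 cannot be read. The step of an at least 3.4-fold higher number from compound 2 to compound 3 (0.53 log units; beyond the scatter) is at least modest. Compound 4 `COc1nc(N)nc2c1c(-c1cccs1)cn2[C@@H]1O[C@H](CO)[C@@H](O)[C@H]1O` differs from compound 3 by thiophen-2-yl in place of furan-3-yl on an aromatic carbon. Among the compounds with values here, no measured step swaps this five-membered ring, so neither step bears on it directly. For compound 4 the expected step is a number no higher from compound 3 to compound 4 (the limit leaves the size open), none beyond the scatter. Compound 4 is estimated at 100000 nM, ranging from 35000 nM to 300000 nM, most likely again a limit.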

Compound 4, half-maximal inhibitory concentration: > 100000 nM
Compound 4 gave a limit, no number; the forecaster's own chance of this, stated with the estimate: 75%; the middle value lies on the limit itself.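

Compound 3 and compound 4 both give only a limit, so the step between them cannot be read: the limit of > 100000 nM in this assay, at which 3 of the 4 values shown sit.

The compounds shown leave open whether thiophen-2-yl in place of furan-3-yl changes the number at all in this assay.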